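The source may report more compounds than this note shows. Statements on the series, on what has been measured and on what is new or still open speak of the compounds shown alone.

Of the compounds shown here, three built on one shared core have been measured in an ADME assay on L929 cells (Mus musculus) for cytotoxicity, read by resazurin assay, with a stated time of 48 h; on this read-out lower numbers stand for higher toxicity in this test and higher numbers for lower toxicity in this test. Compound 1 `C#CCn1c2ccc([N+](=O)[O-])cc2c(=O)n1Cc1ccccc1` gives 195000 nM. Compound 2 `N#CCn1c2ccc([N+](=O)[O-])cc2c(=O)n1Cc1ccccc1` gives > 256000 nM, which is a limit of the assay and not a number. Compound 3 `CN(C)C(=O)CCCn1c2ccc([N+](=O)[O-])cc2c(=O)n1Cc1ccccc1` also gives > 256000 nM, again a limit rather than a number. Compound 2 therefore stands at the limit of > 256000 nM in this assay, at which 2 of the 3 values shown sit, so its own place on the scale is known only as a floor. The step of an at least 1.3-fold higher number from compound 1 to compound 2 (0.11 log units; that floor lies within the scatter) and the step of an at least 1.3-fold higher number from compound 1 to compound 3 (0.11 log units; that floor lies within the scatter) each run from a number to a limit, and the step that the two limits leave unreadable from compound 2 to compound 3 runs between two limits. Compound 4 `O=c1c2cc([N+](=O)[O-])ccc2n(CCCO)n1Cc1ccccc1` alters the same place on the chain as those steps: 2-hydroxyethyl in place of cyano on a saturated chain carbon bound to an aromatic nitrogen. Among the compounds with values here, none of the measured changes at that place has moved the read-out beyond the scatter, and the limits leave the remaining comparison unreadable, so no shift beyond the scatter is expected in this assay for this change either. For compound 4 the estimated value is 256000 nM, with a range from 130000 nM to 500000 nM. That estimate means an expected step of a number no higher from compound 2 to compound 4 (the limit leaves the size open), with a real chance that only a limit is reported once more.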

Compound 4, concentration lethal to 50% of the cells: > 256000 nM
Compound 4 gave a limit, no number; the forecaster's own chance of this, stated with the estimate: 55%; the middle value lies on the limit itself.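

In this assay, the change to 2-hydroxyethyl brings a hydrogen-bond donor onto the chain, which the cyano group it replaces does not have, and compound 4 still ends at a limit and not a number: the limit of > 256000 nM in this assay, at which 3 of the 4 values shown sit.

Set against the only true number among these compounds, the change gives an at least 1.3-fold higher number from compound 1 to compound 4 (0.11 log units; that floor lies within the scatter), so even this comparison does not separate the hydroxy chain from the ethynyl one. The steps that link compound 4 to compound 2 and to compound 3 run between two limits and cannot be read, so a donor-bearing chain at this place has shown no toxicity beyond what the chains without one show, though any true difference among these three would stay hidden.

The compounds shown leave open how far the true values of compound 2, compound 3 and compound 4 lie past the limit, and whether any change at this place moves the read-out beyond the scatter. An amine, a carboxylic acid or a longer chain at this place could test that, ideally with a result that gives a number and not another limit.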